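Methyl position on the thiophene ring in the shared core

The source may hold more compounds than are shown below. What is called first, only, known or untested is meant among the compounds shown, and "the series" means these compounds.

Measured so far in an assay on CHO cells for displacement of a labelled ligand from C-X-C chemokine receptor type 1 (Homo sapiens); on this read-out lower numbers stand for stronger inhibition and higher numbers for weaker inhibition:
compound 1, `CC[C@@H](Nc1c(Nc2cccc(C(=O)N(C)C)c2O)c(=O)c1=O)c1ccc(C)s1`, gives 146 nM.
compound 2, `CC[C@@H](Nc1c(Nc2cccc(C(=O)N(C)C)c2O)c(=O)c1=O)c1cc(C)cs1`, gives 24 nM.

Compound 1 stands highest of the two numbers measured in this assay; its nearest neighbour is compound 2, reached by the step of a 6.1-fold lower number from compound 1 to compound 2 (0.78 log units; beyond the scatter).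

Compound 3, `CC[C@@H](Nc1c(Nc2cccc(C(=O)N(C)C)c2O)c(=O)c1=O)c1sccc1C`, is not yet measured. Its difference from compound 1 is 3-methylthiophen-2-yl in place of 5-methylthiophen-2-yl on a saturated chain carbon bound to a nitrogen on an aromatic ring and a saturated chain carbon. Among the compounds with values here, the only measured step bearing on this change is the one that moves the same methyl to another ring position, a 6.1-fold lower number from compound 1 to compound 2 (0.78 log units; beyond the scatter), which shows that the position of the methyl on the thiophene ring matters in this assay. Nothing measured tells whether a 3-methyl placement behaves like a 4-methyl placement or like the 5-methyl of compound 1, so the direction of the step to compound 3 is open.

Compound 3 is therefore expected to sit between the two measured values, nearer to compound 1, with the step of a 1.8-fold lower number from compound 1 to compound 3 (0.26 log units; within the scatter) as the central expectation. The estimate for compound 3 in this assay is 80 nM, with a range from 20 nM to 300 nM.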

Compound 3, inhibition constant: 123 nM
The estimate for compound 3 lay 1.5-fold (0.19 log units) below the measured number; the range from low to high includes it.
By their numbers in this assay, from the lowest: compound 2; then compounds 3 and 1 (each within the scatter of the next).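

In this assay, 3-methylthiophen-2-yl and 5-methylthiophen-2-yl on the shared core cannot be told apart, with a 1.2-fold lower number from compound 1 to compound 3 (0.07 log units; within the scatter), so moving the methyl does not in itself separate compounds in this series. The same 3-methylthiophen-2-yl is clearly separated from 4-methylthiophen-2-yl, with a 5.1-fold higher number from compound 2 to compound 3 (0.71 log units; beyond the scatter); compound 2 is therefore the one placement of the three that stands apart, with its steps to both of the others printed as beyond the scatter, and the position effect seen earlier belongs to 4-methylthiophen-2-yl rather than to any move of the methyl away from the 5-methyl placement. No measurement at hand offers an explanation for this pattern.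

It remains open how an unsubstituted thiophen-2-yl would compare with these three methyl placements, and whether an ethyl group or a chlorine atom in place of the methyl would keep the distinction shown by compound 2. Also open, going by these compounds, is whether the gap between 4-methylthiophen-2-yl and 3-methylthiophen-2-yl would persist with a butyl chain in place of the propyl chain.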